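The source may hold more compounds than are shown below. What is called first, only, known or untested is meant among the compounds shown, and "the series" means these compounds.

Measured compounds:
compound 1 `Nc1nc(NCc2ccccc2)nc(-c2ccccc2CO)n1`: 4.35 in a functional assay on cells for positive allosteric modulation of G-protein coupled receptor 68 (Homo sapiens), read by a luciferase reporter and cAMP accumulation, with a stated time of 30 min, at pH 6.8 and pH 8.3, in the presence of a further agent that is not named here; on this read-out lower numbers stand for lower potency and higher numbers for higher potency (the scale is a negative logarithm)
compound 2 `CN(C)c1nc(NCc2ccccc2)nc(-c2ccccc2CO)n1`: "not active" (no number reported) in this assay, with no number given

Within the data shown here, compound 1 holds the only number in this assay; compound 2, which differs at the amino group, gives no value at all, so compound 1 stands alone as the single measured point. The step to compound 3 `CC(=O)c1ccccc1-c1nc(N)nc(NCc2ccccc2)n1` alters the group on the aromatic ring: acetyl in place of hydroxymethyl on an aromatic carbon. Among the measured compounds shown here, no step between two measured compounds is available to set a scale for this change. Since compound 1 gives 4.35 and that value is low, a shift of modest size in either direction is expected, and the result could well remain within the scatter. Compound 3 is expected to give 4.3 in this assay, between 3.6 and 5. This estimate means an expected step of a number 0.05 log units lower from compound 1 to compound 3 (within the scatter), no larger than the scatter.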

Compound 3, negative logarithm of the antagonist equilibrium constant: "not active" (no number reported)
For compound 3 the study gives words and no number; the estimate stays without a comparison.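

In this assay compound 3 is reported as not active, without a number, so no step can be read from compound 1 at 4.35. The compounds shown leave open how far acetyl in place of hydroxymethyl shifts potency. No measurement shown here bears on this result.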